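The source may hold more compounds than are shown below. What is called first, only, known or untested is meant among the compounds shown, and "the series" means these compounds.

Of the compounds shown here, two have been measured in an assay on isolated protein for binding affinity to C-X-C chemokine receptor type 1 (Homo sapiens); on this read-out lower numbers stand for stronger inhibition and higher numbers for weaker inhibition. Compound 1 `C[C@H](Nc1n[s+]([O-])nc1Nc1cccc(C(=O)N(C)C)c1O)C(C)(C)C` gives 484 nM there; compound 2 `CC(C)[C@@H](NC1=NS(=O)(=O)N=C1Nc1cccc(C(=O)N(C)C)c1O)c1cccc(F)c1` gives 652 nM in this assay, and the two numbers lie within the usual scatter of each other, so neither is set apart. Compound 3 `CC[C@@H](Nc1n[s+]([O-])nc1Nc1cccc(C(=O)N(C)C)c1O)c1ccc(C)o1` is not yet measured. It differs from compound 1 in one place: 1-(5-methylfuran-2-yl)propyl in place of 1,2,2-trimethylpropyl on a nitrogen on an aromatic ring. Among the compounds with values here, no measured pair isolates this change. The step from compound 1 to compound 3 is expected to be a 1.1-fold higher number from compound 1 to compound 3 (0.06 log units; within the scatter), not beyond the scatter, since compound 2 with an aromatic ring on the same nitrogen shows 652 nM. Compound 3 is estimated at 550 nM, range 200 nM to 1500 nM.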

Compound 3, inhibition constant: 234 nM
The estimate for compound 3 lay 2.4-fold (0.37 log units) above the measured number; low and high end bracket the measured number.
By their numbers in this assay, from the lowest: compound 3; then compounds 1 and 2 (each within the scatter of the next).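

In this assay, within the data shown here, the nitrogen on the aromatic ring accepts 1-(5-methylfuran-2-yl)propyl, and the change gives a 2.1-fold lower number from compound 1 to compound 3 (0.32 log units; beyond the scatter) as the first step at this position beyond the scatter. The entering group differs in several ways at once, with more heavy atoms, a five-membered aromatic ring and a hydrogen-bond acceptor, and this single step does not separate them. Nothing available bears on the origin of the step.

Still open, going by these compounds, is whether the ring oxygen matters, which 1-(5-methylthiophen-2-yl)propyl would address. 1-(Furan-2-yl)propyl would address the methyl on the ring.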